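The source may hold more compounds than are shown below. What is called first, only, known or untested is meant among the compounds shown, and "the series" means these compounds.

Measured compounds in an assay for binding affinity to Cholecystokinin receptor (Rattus norvegicus), read by CCK-8 assay; a higher number here means a weaker inhibitor, a lower number a stronger inhibitor:
- compound 1, `CC(C)(C)OC(=O)CN1C(=O)C(NC(=O)CCc2c[nH]c3ccccc23)CCc2ccccc21`: 2000 nM
- compound 2, `CC(C)(C)OC(=O)CN1C(=O)C(NC(=O)c2cc3ccccc3[nH]2)CCc2ccccc21`: 7 nM
- compound 3, `O=C(NC1CCc2ccccc2N(Cc2ccccc2)C1=O)c1cc2ccccc2[nH]1`: 35 nM

Among these three, compound 2 gives the lowest number, and both of its steps to the others lie beyond the scatter: a 290-fold lower number from compound 1 to compound 2 (2.46 log units; beyond the scatter), and a 5.0-fold higher number from compound 2 to compound 3 (0.70 log units; beyond the scatter). The move from compound 1 to compound 2 exchanges the 2-(1H-indol-3-yl)ethyl on the carbonyl carbon for 1H-indol-2-yl; the move from compound 2 to compound 3 exchanges the tert-butoxycarbonyl on the saturated chain carbon bound to the ring amide nitrogen for phenyl.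

The step to compound 4, `CC(C)(C)OC(=O)CN1C(=O)[C@@H](NC(=O)c2cc3ccccc3[nH]2)CCc2ccccc21`, is of a different kind: the two compounds have the same atoms and bonds; at least one stereo element is drawn with a configuration in one of them and without one in the other: 1 of 1 stereo elements differ; a stereocentre at a saturated ring carbon is drawn without a configuration in compound 2 and S in compound 4. Compound 2 therefore contains the same molecule as compound 4 without the configuration at that ring carbon being fixed, while compound 4 is the single S form. Within the data shown here, neither measured step touches a stereocentre, so neither bears directly on this change; the only anchor is the value of compound 2 itself. A single enantiomer drawn from a mixture can give a number somewhat lower than the mixture or, if it is the less active form, a clearly higher one. Compound 4 is estimated at 4 nM, within 1.5 nM to 30 nM, which means an expected step of a 1.8-fold lower number from compound 2 to compound 4 (0.24 log units; within the scatter).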

Compound 4, half-maximal inhibitory concentration: 200 nM
The estimate for compound 4 lay 50-fold (1.70 log units) below the measured number; the measured number lies above the stated range.
By their numbers in this assay, from the lowest: compound 2; then compound 3; then compound 4; then compound 1.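

In this assay, a change in drawn configuration alone, with no atom or bond altered, gives a large step: a 29-fold higher number from compound 2 to compound 4 (1.46 log units; beyond the scatter). Among these compounds, none of the earlier steps could show this, since each exchanged one group for another; this one shows that the three-dimensional arrangement at the saturated ring carbon matters in its own right, and here it counts for more than the step of a 5.0-fold higher number from compound 2 to compound 3 (0.70 log units; beyond the scatter). If compound 2 holds both forms at that carbon, the S form cannot account for its low number, and most of the binding would have to come from the R form, a reading that rests only on this one difference between the two drawings: the fact that one of compounds 2 and 4 is drawn with a defined configuration and the other without, at the place where they differ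

Going by these compounds, the value of the single R form remains open, as does the exact composition of compound 2, so how much lower than compound 2 the R form might lie cannot be said. Also open, on these data alone, is whether the same preference at this carbon holds with the phenyl of compound 3, or with a carboxylic acid in place of the tert-butoxycarbonyl.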